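The compounds below may be only part of what the source reports. "The series", "measured", "known", "first", "only" and "open" are said of these compounds alone.

Compound 1 `CCCc1ccc(-c2cc(=O)c3c(o2)C(CC)(CC)C(=O)C(CC)=C3O)cc1`: > 53 uM, a limit.
Compound 2 `CCC1=C(O)c2c(oc(-c3ccc(Br)cc3)cc2=O)C(CC)(CC)C1=O`: > 48.1 uM, a limit.
Compound 3 `CCC1=C(O)c2c(oc(-c3cc(C)ccc3C)cc2=O)C(CC)(CC)C1=O`: 14.5 uM.

All three compounds were tested in a functional assay on KB cells (Homo sapiens) for antiproliferative activity, read by sulforhodamine B assay, with a stated time of 3 days; on this read-out higher numbers stand for an effect only at larger amounts of compound and lower numbers for an effect already at smaller amounts. Compound 3 at 14.5 uM is the only one of the three with a true number. The other two results are limits.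

Compound 4 `CCC1=C(O)c2c(oc(-c3cc(C)ccc3F)cc2=O)C(CC)(CC)C1=O` keeps the shared core and alters one group: fluoro in place of methyl on an aromatic carbon. In words, this is fluoro in place of methyl on an aromatic carbon, ortho to a large group, or 2,5-dimethylphenyl to 2-fluoro-5-methylphenyl.

Within the data shown here, no measured step makes this exact exchange. The nearest evidence comes from swapping the whole substituted phenyl group: an at least 3.6-fold lower number from compound 1 to compound 3 (0.56 log units; beyond the scatter) and an at least 3.3-fold lower number from compound 2 to compound 3 (0.52 log units; beyond the scatter), both beyond the scatter. The third step, a step that the two limits leave unreadable from compound 1 to compound 2, cannot be read. Among the measured compounds shown here, in compound 4 only one group changes, so a smaller step is expected in this assay, probably within the scatter. The slight lean towards a higher number rests on compound 3 at 14.5 uM being the only one of the three with a true number. The expected change is a 1.4-fold higher number from compound 3 to compound 4 (0.14 log units; within the scatter). For compound 4 the estimated value is 20 uM, with an expected range from 8 uM to 48 uM.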

Compound 4, concentration for half-maximal effect: 47.3 uM
For compound 4 the middle estimate is 2.4-fold (0.37 log units) below the measured one; low and high end bracket the measured number.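

The earlier steps shown here each exchanged a whole substituted phenyl group, so they could not show what one group on that ring contributes. In this assay, replacing only the methyl ortho to a large group with fluoro, one heavy atom for one heavy atom, gives a 3.3-fold higher number from compound 3 to compound 4 (0.51 log units; beyond the scatter), so this single place is enough to move the read-out beyond the usual scatter, towards needing more compound. The comparisons with the two earlier limits give only floors, an at least 1.0-fold lower number from compound 2 to compound 4 (0.00 log units; that floor lies within the scatter) and an at least 1.1-fold lower number from compound 1 to compound 4 (0.04 log units; that floor lies within the scatter), so neither pair can be put in order, and the true value of compound 2 remains unknown because its result is only a limit: the limit of > 48.1 uM in this assay, at which 1 of the 4 values shown sits.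

How far compound 1 truly lies from compound 4 also stays open, because its result is likewise only a limit: the limit of > 53 uM in this assay, at which 1 of the 4 values shown sits. The compounds shown further leave open how a chloro group, a methoxy group or an amine would read at this same place, ortho to a large group, and so whether methyl is unusual there or fluoro is.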